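This account rests on a few compounds, and the source may have more. Where it says the series, first, only, none or still open, it means among the compounds named here.

In a physicochemical assay for solubility, at pH 6.8 (on this read-out higher numbers stand for higher solubility and lower numbers for lower solubility), compound 1 `O=C(NCc1cccnc1)Nc1ccc(CNC(=O)c2ccc(CN3CCNCC3)cc2)cc1` gives > 1000000 nM, which is a limit of the assay and not a number. Among the compounds with values here, compound 2 `CCC(=O)N[C@@H](C)c1ccc(NC(=O)[C@H]2C[C@@H]2c2cccnc2)cc1` gives 54000 nM, the only true number so far. Compound 3 `C[C@H](NC(=O)C1CCOCC1)c1ccc(NC(=O)[C@H]2C[C@@H]2c2cccnc2)cc1` has oxan-4-yl in place of ethyl on a carbonyl carbon. Within the data shown here, no measured pair of compounds shows what such a change does, so in this assay the expected result is no step beyond the usual scatter, an estimated 1.1-fold lower number from compound 2 to compound 3 (0.03 log units; within the scatter), and either direction remains possible. Compound 3 is estimated at 50000 nM, with an expected range from 15000 nM to 200000 nM.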

Compound 3, solubility: 90000 nM
The estimate for compound 3 lay 1.8-fold (0.26 log units) below the measured number, and the stated range covers the measured number.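

In this assay, within the data shown here, the one step at this position is a 1.7-fold higher number from compound 2 to compound 3 (0.22 log units; within the scatter). Oxan-4-yl is a larger group than ethyl on this carbonyl carbon, bringing a six-membered ring and a hydrogen-bond acceptor, yet for this pair the read-out stays within the usual scatter. Nothing shown gives a reason for this result.

Going by these compounds, it remains open what a piperidin-4-yl group, which carries an amine, or a carboxylic acid would do in the same place. On these data alone, it is also open whether any group on this carbonyl carbon moves the number beyond the scatter.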